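Ester to methyl ketone on a weak-growth-inhibitor core

This account rests on a few compounds, and the source may have more. Where it says the series, first, only, none or still open, it means among the compounds named here.

Measured compounds, all in a functional assay on UACC-62 cells (Homo sapiens) for inhibition, read by sulforhodamine B assay, with a stated time of 48 h; on this read-out higher numbers stand for weaker inhibition of growth and lower numbers for stronger inhibition of growth:
compound 1 `C=C(C)[C@@H]1CC=C(Cn2cc(COc3cccc(C4NC(=O)NC(C)=C4C(=O)OCC)c3)nn2)CC1` gives 22900 nM
compound 2 `C=C(C)[C@@H]1CC=C(Cn2cc(COc3ccccc3C3NC(=O)NC(C)=C3C(=O)OCC)nn2)CC1` gives only a limit, > 100000 nM
compound 3 `C=C(C)[C@@H]1CC=C(Cn2cc(COc3cc(C4NC(=O)NC(C)=C4C(=O)OCC)ccc3OC)nn2)CC1` gives 37800 nM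

Compound 2 stands at the weak end of the numbers shown. In this assay compound 2 has no number of its own, only a limit of the assay, > 100000 nM; this is the limit of > 100000 nM in this assay, at which 1 of the 3 values shown sits. Among the compounds with values here, compounds 1 and 3, which carry the same core at other positions of the aromatic ring, both give measured numbers, and the one measured step, a 1.7-fold higher number from compound 1 to compound 3 (0.22 log units; within the scatter), is small.

Compound 4 `C=C(C)[C@@H]1CC=C(Cn2cc(COc3ccccc3C3NC(=O)NC(C)=C3C(C)=O)nn2)CC1` differs from compound 2 in one place: methyl in place of ethoxy on a carbonyl carbon. Within the data shown here, none of the measured steps touches this carbonyl group; the only measured step concerns a methoxy on an aromatic carbon and stays within the scatter. Among the measured compounds shown here, nothing among the measured compounds therefore points in either direction for the ester-to-ketone change, and compound 2 itself sits at the limit, so a number for compound 4 may again not be reached.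

The expected step is a number no higher from compound 2 to compound 4 (the limit leaves the size open), that is, none beyond the scatter. Compound 4 is estimated at 100000 nM, with a range from 30000 nM to 300000 nM.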

Compound 4, concentration for total growth inhibition: 34200 nM
Compound 4: middle estimate off by 2.9-fold (0.47 log units), on the high side, within the range that was stated.
By their numbers in this assay, from the lowest: compounds 1, 4 and 3 (each within the scatter of the next). At a limit, above all of these: compound 2.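

In this assay, within the data shown here, methyl in place of ethoxy on a carbonyl carbon gives an at least 2.9-fold lower number from compound 2 to compound 4 (0.46 log units; beyond the scatter), so the group on this carbonyl carbon matters to the read-out, which the earlier compounds could not show, as their only measured step concerned a methoxy on the aromatic ring and stayed within the scatter. With the acetyl group, compound 4 has a measured number, whereas compound 2 with the ethoxycarbonyl group has none of its own, and the step can therefore be read in one direction only, with its full size left open, because the value of compound 2 is only a limit: the limit of > 100000 nM in this assay, at which 1 of the 4 values shown sits. This finding rests on a single pair and describes only the change from ethoxycarbonyl to acetyl on the core shared by compound 2 and compound 4.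

The compounds shown leave open how an amide, a carboxylic acid or a longer chain would read on this carbonyl carbon. They also leave open whether the same change from ethoxycarbonyl to acetyl would give a similar step on the core of compound 1 or compound 3.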